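Replacing a tert-butyl with an imidazolylsulfanylmethyl arm

The source may report more compounds than this note shows. Statements on the series, on what has been measured and on what is new or still open speak of the compounds shown alone.

Of the compounds shown here, three have so far been measured in an assay for inhibition of Amine oxidase [flavin-containing] A (Homo sapiens), read by fluorescence and spectrophotometry, using microsomes, with stated times of 30 min and 20 min; on this read-out lower numbers stand for stronger inhibition and higher numbers for weaker inhibition. Compound 1 `Cn1ncc2c(c1=O)Oc1ccccc1C1=NCCN12` gives only a limit, > 100000 nM, which marks the edge of the assay rather than a number (the limit of > 100000 nM in this assay, at which 1 of the 3 values shown sits). Compound 2 `CC(C)(C)c1ccc(-c2noc(-c3ccc(C4=NCCN4)cc3)n2)cc1` gives 751 nM, the lower of the two real numbers. Within the data shown here, compound 3 `Cc1ccc(Cc2noc(-c3ccc(C4=NCCN4)cc3)n2)cc1` gives 55500 nM, a higher number than that of compound 2, and the gap between these two lies well beyond the usual scatter; since the two structures differ in more than one place, no single step can be drawn between them.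

Compound 4 `Cn1ccnc1SCc1ccc(-c2noc(-c3ccc(C4=NCCN4)cc3)n2)cc1` has not yet been measured. It differs from compound 2 in one place: ((1-methyl-1H-imidazol-2-yl)sulfanyl)methyl in place of tert-butyl on an aromatic carbon. A small, compact hydrocarbon group is thus exchanged for a considerably larger group carrying its own ring. Among the measured compounds shown here, no measured pair in this set shows a change of this kind, so the direction rests on judgment alone. The expectation is a moderate weakening, a step from compound 2 to compound 4 of a 4.0-fold higher number from compound 2 to compound 4 (0.60 log units; beyond the scatter) in this assay. Compound 4 is therefore estimated at 3000 nM, with a likely range from 700 nM to 15000 nM.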

Compound 4, half-maximal inhibitory concentration: 12400 nM
Compound 4: the middle estimate sits 4.1-fold (0.62 log units) below what was measured; measured number inside the range.
By their numbers in this assay, from the lowest: compound 2; then compound 4; then compound 3. At a limit, above all of these: compound 1.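

Among these compounds, this is the first step that can be read at this position, on an aromatic carbon para to a large group, and it shows that the position is sensitive to what sits there: in this assay, putting ((1-methyl-1H-imidazol-2-yl)sulfanyl)methyl in place of tert-butyl gives a 17-fold higher number from compound 2 to compound 4 (1.22 log units; beyond the scatter). The entering arm is the larger of the two by heavy atoms and brings a five-membered aromatic ring, yet compound 4 still gives a real number and not a limit of the assay, so inhibition is reduced but remains measurable with this large arm in place. No measurement shown accounts for the size of this step, and a single pair cannot explain it.

The step changes several things at once, so it leaves open whether the loss follows from the imidazole ring, the sulfur link or the greater length of the arm. A plain butyl chain, a methoxymethyl arm or a dimethylaminomethyl group at the same position on the shared core would help to separate these possibilities.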